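A few compounds are considered here, and "the series" means these few. Any claim that something is new, unique, unknown or untested is made for them only; others in the source may bear on it.

Compounds measured in an in vitro assay on HEK-tsA201 cells for antagonist activity at Neuronal acetylcholine receptor; alpha3/beta4 (Homo sapiens), read by fluorescence and calcium flux; on this read-out higher numbers stand for weaker inhibition and lower numbers for stronger inhibition:
Compound 1 `CCCNc1cccc(NC(=O)c2ccc(OCCC)cc2)n1` gives 12600 nM in this assay.
Compound 2 `CCCCCCNc1cccc(NC(=O)c2ccc(OCCC)cc2)n1` reaches only the limit > 100000 nM in this assay.
Compound 3 `CCCOc1ccc(C(=O)Nc2cccc(Nc3ccccc3)n2)cc1` reaches only the limit > 100000 nM in this assay.

Compound 3 thus stands at the limit and carries no number; the limit of > 100000 nM in this assay, at which 2 of the 3 values shown sit, applies to it as well as to compound 2. Of the measured steps, an at least 7.9-fold higher number from compound 1 to compound 2 (0.89 log units; beyond the scatter) and an at least 7.9-fold higher number from compound 1 to compound 3 (0.89 log units; beyond the scatter) both run toward weaker inhibition, while a step that the two limits leave unreadable from compound 2 to compound 3 cannot be read. Compound 4 `CCCOc1ccc(C(=O)Nc2cccc(Nc3ccccc3F)n2)cc1` differs from compound 3 by fluoro in place of hydrogen on an aromatic carbon. For the measured compounds named here, none of the measured steps changes the anilino group in this way, so no step bears on it directly; the steps that exist point toward weakening, and compound 3 already sits at the limit. Compound 4 is therefore expected to remain at or near the limit, with a number no higher from compound 3 to compound 4 (the limit leaves the size open) as the expected step. The estimate for compound 4 in this assay is 100000 nM, in the range 30000 nM to 300000 nM.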

Compound 4, half-maximal inhibitory concentration: > 100000 nM
Compound 4: a limit, no number (the forecaster's own chance of this, stated with the estimate: 75%); the middle value sits exactly at the limit.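

In this assay, 2-fluorophenyl in place of propyl on the nitrogen gives an at least 7.9-fold higher number from compound 1 to compound 4 (0.89 log units; beyond the scatter), so a third group on this nitrogen, after hexyl and phenyl, reads toward weaker inhibition than the propyl of compound 1. Compound 4 gives > 100000 nM, which is a limit. The steps to compound 4 from compound 2 and from compound 3 cannot be read, so fluoro in place of hydrogen has no readable effect here: the limit of > 100000 nM in this assay, at which 3 of the 4 values shown sit.

As far as these compounds go, whether an ethyl or a butyl on this nitrogen reads differently from the propyl of compound 1 stays open. Also open, from the compounds shown here alone, is what fluoro in place of hydrogen does in a compound that gives a number rather than a limit.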